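This account rests on a few compounds, and the source may have more. Where it says the series, first, only, none or still open, it means among the compounds named here.

Measured compounds:
compound 1 `CCC(=O)Oc1ccc(C(=O)C2=C3OC(C)(C)[C@@H](CC=C(C)C)C[C@@]34C[C@@H](CC=C(C)C)C(C)(C)[C@H]3CCC(C)(C)O[C@]34OC2=O)cc1OC(=O)CC`: > 20000 nM
compound 2 `CCCCCC(=O)Oc1ccc(C(=O)C2=C3OC(C)(C)[C@@H](CC=C(C)C)C[C@@]34C[C@@H](CC=C(C)C)C(C)(C)[C@H]3CCC(C)(C)O[C@]34OC2=O)cc1OC(=O)CCCCC`: > 20000 nM
compound 3 `CC(C)=CC[C@H]1C[C@]23C[C@@H](CC=C(C)C)C(C)(C)[C@H]4CCC(C)(C)O[C@]42OC(=O)C(C(=O)c2ccc(OC(=O)c4ccccc4)c(OC(=O)c4ccccc4)c2)=C3OC1(C)C`: > 20000 nM

All three were tested in a functional assay on K562 cells (Homo sapiens) for antiproliferative activity, read by MTT assay, with a stated time of 72 h; on this read-out lower numbers stand for stronger inhibition and higher numbers for weaker inhibition. The result for compound 1 is a limit of the assay rather than a number: compound 1 gives > 20000 nM. Compound 2 likewise returns only a limit, giving > 20000 nM. For compound 3 the result is again a limit, > 20000 nM. Compound 1 thus stands at the edge of what this assay can report, and nothing distinguishes it from the other two, since (the limit of > 20000 nM in this assay, at which 3 of the 3 values shown sit). Within the data shown here, no step between two measured compounds that differ in a single place is available.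

Compound 4 `CCC(=O)Oc1cc(C(=O)C2=C3OC(C)(C)[C@@H](CC=C(C)C)C[C@@]34C[C@@H](CC=C(C)C)C(C)(C)[C@H]3CCC(C)(C)O[C@]34OC2=O)ccc1O` has not yet been measured. It differs from compound 1 in one place: hydrogen in place of propanoyl on an oxygen on an aromatic ring. Cut one bond further out, the same difference reads propanoyloxy to hydroxy. With every measured value sitting at a limit, the data give no guide to how far such a change reaches. The expected step of an at least 2.5-fold lower number from compound 1 to compound 4 (0.39 log units; beyond the scatter) is a gain in potency somewhat beyond the scatter, although a further limit remains a real possibility. For compound 4 in this assay a value of about 8000 nM is estimated, within a range from 1500 nM to 20000 nM.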

Compound 4, half-maximal inhibitory concentration: 12100 nM
The estimate for compound 4 lay 1.5-fold (0.18 log units) below the measured number; low and high end bracket the measured number.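

In this assay, among these compounds, compound 4 gives 12100 nM, the first actual number in this small set, so the exchange of propanoyloxy for hydroxy is the first change here whose effect can be read at all. The step is an at least 1.6-fold lower number from compound 1 to compound 4 (0.21 log units; that floor lies within the scatter); it rests on a limit for compound 1, so it gives only a floor, and the true difference may be larger, although the floor itself does not clear the usual scatter. What the earlier compounds could not show, sitting alike as they did, is that a change on an oxygen on an aromatic ring can bring the read-out within the range of the assay: the limit of > 20000 nM in this assay, at which 3 of the 4 values shown sit.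

The compounds shown leave open whether the free hydroxy itself matters or only the loss of the propanoyl, a question that a methoxy group or an amine at the same place would help to settle. They also leave open whether the same exchange would bring a measurable number in the hexanoyl and benzoyl compounds, and what would follow if the remaining propanoyl of compound 4 were replaced as well.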